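Trifluoromethyl in Place of Fluoromethyl: An Aortic Response Estimate

This account rests on a few compounds, and the source may have more. Where it says the series, first, only, none or still open, it means among the compounds named here.

Of the compounds shown here, two sharing one core have been measured in a functional assay on the whole organism (aorta) with Rattus norvegicus as the target; on this read-out lower numbers stand for smaller maximal responses and higher numbers for larger maximal responses. Compound 1 `C/N=C(/S)C1=CC(C)(C(F)(F)F)Oc2ccc([N+](=O)[O-])cc21` gives 62.5%. Compound 2 `CNC(=O)C1=CC(C)(CF)Oc2ccc([N+](=O)[O-])cc21` gives 66%. Of these two numbers compound 2 holds the higher one, yet its nearest neighbour, compound 1, sits within the usual scatter of such measurements, so the two values show no difference that can be trusted.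

Compound 3 `CNC(=O)C1=CC(C)(C(F)(F)F)Oc2ccc([N+](=O)[O-])cc21` differs from compound 2 in one place: trifluoromethyl in place of fluoromethyl on a saturated ring carbon. Within the data shown here, no step between measured compounds isolates this change; compound 1 also carries trifluoromethyl, but it differs from compound 2 in a second place, so its value is no direct guide. Given the small spread of the two measured values, the step expected here is a number 2 percentage points lower from compound 2 to compound 3 (within the scatter), none beyond the scatter. For compound 3 the expected value in this assay is 64%, within a range from 50% to 78%.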

Compound 3, intrinsic activity: the largest response reached, in percent of the reference agonist's: 61.7%
Compound 3: middle estimate off by 2.3 percentage points, on the high side; low and high end bracket the measured number.
By their numbers in this assay, from the lowest: compounds 3, 1 and 2 (each within the scatter of the next).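

In this assay the swap on the saturated ring carbon can now be read directly: trifluoromethyl in place of fluoromethyl gives a number 4.3 percentage points lower from compound 2 to compound 3 (within the scatter), so the larger fluorinated group leaves no difference that can be trusted at this position. The methylcarbamoyl group in place of the sulfur-bearing group on the double-bonded ring carbon gives a number 0.8 percentage points lower from compound 1 to compound 3 (within the scatter), so compound 1 and compound 3 cannot be told apart on this read-out either. The data offered here contain nothing that would explain these results.

On these data alone, whether a plain methyl, an ethyl or a hydroxymethyl group on this saturated ring carbon would shift the maximal response beyond the scatter remains open. So does the outcome of pairing fluoromethyl with the sulfur-bearing group.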